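Fluorine pattern on the benzyl group of a hindered phenol series

The compounds below may be only part of what the source reports. "The series", "measured", "known", "first", "only" and "open" are said of these compounds alone.

Compound 1 `CC(C)(C)c1cc(/C=C/C(=O)NCCC2CCN(Cc3ccccc3)CC2)cc(C(C)(C)C)c1O` in an assay on isolated protein for inhibition of Amine oxidase [flavin-containing] A (Homo sapiens), read by fluorescence, with stated times of 15 min and 20 min (a lower number here means a stronger inhibitor, a higher number a weaker inhibitor), gives 62300 nM. Compound 2 `CC(C)(C)c1cc(/C=C/C(=O)NCCC2CCN(Cc3cccc(F)c3)CC2)cc(C(C)(C)C)c1O` gives 58400 nM in this assay. Among the measured compounds shown here, the step of a 1.1-fold lower number from compound 1 to compound 2 (0.03 log units; within the scatter) lies within the scatter, so compound 2 sits level with compound 1, the only other number available. Compound 3 `CC(C)(C)c1cc(/C=C/C(=O)NCCC2CCN(Cc3ccc(F)cc3F)CC2)cc(C(C)(C)C)c1O` carries 2,4-difluorophenyl in place of 3-fluorophenyl on a saturated chain carbon bound to an amine nitrogen in a ring. For the measured compounds named here, the one measured step that bears on this, a 1.1-fold lower number from compound 1 to compound 2 (0.03 log units; within the scatter), left the number unchanged beyond the scatter. A further fluorine is therefore expected to leave this assay essentially flat, the estimated step being a 1.1-fold lower number from compound 2 to compound 3 (0.03 log units; within the scatter). Compound 3 is estimated at 55000 nM, within 25000 nM to 120000 nM.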

Compound 3, half-maximal inhibitory concentration: 70600 nM
Estimate against measurement, compound 3: 1.3-fold (0.11 log units) below; the range from low to high includes it.
By their numbers in this assay, from the lowest: compounds 2, 1 and 3 (each within the scatter of the next).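

In this assay, the 2,4-difluorobenzyl group reads level with both other benzyl groups (a 1.2-fold higher number from compound 2 to compound 3 (0.08 log units; within the scatter)) and (a 1.1-fold higher number from compound 1 to compound 3 (0.05 log units; within the scatter)). A second fluorine therefore gives no step beyond the scatter, and across compound 1, compound 2 and compound 3 this position shows no response to the number or pattern of fluorines. No measurement shown offers an explanation for this flat result.

Still open, on these data alone, is whether a methoxy group or a carboxylic acid on the benzyl ring would move the number. The same holds for a phenethyl group in place of the benzyl group.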